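The source may report more compounds than this note shows. Statements on the series, on what has been measured and on what is new or still open speak of the compounds shown alone.

Compounds measured in a functional assay on MCF7 cells (Homo sapiens) for antiproliferative activity, read by sulforhodamine B assay, with a stated time of 48 h; a lower number here means a stronger inhibitor, a higher number a weaker inhibitor:
compound 1 `CC(C)c1ccccc1OS(=O)(=O)c1cccc(NC(=O)CCCl)c1`, 12000 nM
compound 2 `CCCC(=O)Nc1ccc(S(=O)(=O)Oc2ccccc2C(C)C)cc1`, 6600 nM
compound 3 `CCCC(=O)Nc1ccc(S(=O)(=O)Oc2ccccc2I)cc1`, 9700 nM

Compound 3 stands second highest of the three numbers; the nearest value is that of compound 1, the furthest that of compound 2, and both gaps lie within the scatter, so no order among the three is claimed. Among the measured compounds shown here, the single measured step, a 1.5-fold higher number from compound 2 to compound 3 (0.17 log units; within the scatter), concerns an aromatic carbon and not the carbonyl carbon. Compound 4 `O=C(NCC1CCCC1)Nc1ccc(S(=O)(=O)Oc2ccccc2I)cc1` carries (cyclopentylmethyl)amino in place of propyl on a carbonyl carbon. For the measured compounds named here, no measured step bears on this change; the series offers no guidance on replacing the propylcarbonyl. The expectation for compound 4 is therefore a step of a 1.1-fold lower number from compound 3 to compound 4 (0.03 log units; within the scatter) in this assay, nothing beyond the scatter. The estimated value for compound 4 in this assay is 9000 nM, with a range from 3000 nM to 30000 nM.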

Compound 4, half-maximal inhibitory concentration: 6600 nM
Beside the measured number, compound 4's estimate is 1.4-fold (0.13 log units) above it, and the stated range covers the measured number.
By their numbers in this assay, from the lowest: compounds 2, 4, 3 and 1 (each within the scatter of the next).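

The change of propyl to (cyclopentylmethyl)amino on a carbonyl carbon gives a 1.5-fold lower number from compound 3 to compound 4 (0.17 log units; within the scatter) in this assay. Among the compounds shown here, this is the first reading at this position: a group of 7 heavy atoms with a five-membered non-aromatic ring and a hydrogen-bond donor replaces one of 3 heavy atoms, with no shift beyond the scatter. No supporting measurement bears on this result.

On these data alone, whether a carboxylic acid or a longer alkyl chain on this carbonyl carbon would move the number beyond the scatter remains open.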